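The source may hold more compounds than are shown below. What is called first, only, known or untested is meant among the compounds shown, and "the series" means these compounds.

Measured in a functional assay on A549 cells (Homo sapiens) for antiproliferative activity, read by MTT assay, with a stated time of 72 h; a higher number here means a weaker inhibitor, a lower number a stronger inhibitor:
- compound 1 `COc1ccc(N2C(=O)COc3ccc(-c4cnc(Cl)c(NS(=O)(=O)c5ccc(F)cc5)c4)cc32)cc1`: 30400 nM
- compound 2 `COc1ncc(-c2ccc3c(c2)N(C2CCCCC2)C(=O)CO3)cc1NS(=O)(=O)c1ccc(F)cc1`: 24600 nM
- compound 3 `COc1ncc(-c2ccc3c(c2)N(C2CC2)C(=O)CO3)cc1NS(=O)(=O)c1ccc(F)cc1`: 3320 nM

Compound 3 has the lowest number of the three, and both others lie beyond the scatter from it. Next in the series is compound 4 `COc1ccc(N2C(=O)COc3ccc(-c4cnc(OC)c(NS(=O)(=O)c5ccc(F)cc5)c4)cc32)cc1`, which has 4-methoxyphenyl in place of cyclopropyl on an amide-type nitrogen in a ring.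

Going by the values given here, one measured step bears directly on this nitrogen: a 7.4-fold lower number from compound 2 to compound 3 (0.87 log units; beyond the scatter), a modest change on going from cyclohexyl to cyclopropyl. Among the compounds with values here, no measured step isolates 4-methoxyphenyl. Compound 1 carries that group on the same nitrogen and gives 30400 nM, but it also differs from compound 4 elsewhere, so it is only a loose guide. Cyclopropyl is so far the substituent with the lower number, so a move to a higher number is expected in this assay, of similar size to the measured step. The expected step is a 3.3-fold higher number from compound 3 to compound 4 (0.52 log units; beyond the scatter). For compound 4 the estimate is 11000 nM, with an expected range of 3000 nM to 40000 nM.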

Compound 4, half-maximal inhibitory concentration: 1350 nM
For compound 4 the middle estimate is 8.1-fold (0.91 log units) above the measured one; measured number below the stated range.
By their numbers in this assay, from the lowest: compound 4; then compound 3; then compounds 2 and 1 (each within the scatter of the next).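

In this assay an aromatic ring on the amide-type nitrogen is well tolerated, with a 2.5-fold lower number from compound 3 to compound 4 (0.39 log units; beyond the scatter) and an 18-fold lower number from compound 2 to compound 4 (1.26 log units; beyond the scatter); a six-membered ring at this position is therefore not unfavourable in itself, although the cyclohexyl of compound 2 gives the poorer result. The 4-methoxyphenyl group does not suffice alone, as a 23-fold lower number from compound 1 to compound 4 (1.35 log units; beyond the scatter) shows that swapping chloro for methoxy on an aromatic carbon has the largest effect seen in this set, with the nitrogen substituent unchanged. Nothing at hand explains either step.

From the compounds shown here alone, whether the methoxy on the phenyl ring contributes remains open, and plain phenyl or 4-fluorophenyl on the nitrogen would address that. Also open, going by these compounds, is whether the chloro-to-methoxy step has the same size with cyclopropyl on the nitrogen.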